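This account rests on a few compounds, and the source may have more. Where it says the series, first, only, none or still open, it means among the compounds named here.

Measured compounds:
- compound 1, `COC1=C[C@H](O)[C@H](C/C=C(\C)CC/C=C(\C)CCC=C(C)C)[C@@H](C)C1=O`: 16400 nM
- compound 2, `COC1=C[C@H](O)[C@H](C/C=C(\C)CC/C=C(\C)C[C@@H]2C[C@@H](C)C(=O)O2)[C@@H](C)C1=O`: > 30000 nM

Both compounds were tested in a functional assay on A549 cells (Homo sapiens) for inhibition, read by sulforhodamine B assay, with a stated time of 48 h; a lower number here means a stronger inhibitor of growth, a higher number a weaker inhibitor of growth. In this assay compound 1 gives 16400 nM. For compound 2 the assay reports only a limit, > 30000 nM, so no exact number is known for it. Compound 2 thus sits at the limit of > 30000 nM in this assay, at which 1 of the 2 values shown sits, and stands as the weaker-looking of the two only within that bound. For the measured compounds named here, the one measured step is an at least 1.8-fold higher number from compound 1 to compound 2 (0.26 log units; that floor lies within the scatter), a change at the end of the chain.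

Compound 3, `COC1=C(OC)[C@H](O)[C@H](C/C=C(\C)CC/C=C(\C)C[C@@H]2C[C@@H](C)C(=O)O2)[C@@H](C)C1=O`, is not yet measured. It differs from compound 2 in the shared core: methoxy in place of hydrogen on a double-bonded ring carbon. No measured step touches this part of the molecule, so nothing among the shown numbers speaks for a shift in either direction from this change. The expectation for compound 3 is therefore a step of no real size, a step that the limit leaves unreadable from compound 2 to compound 3, beyond the usual scatter. Compound 3 is accordingly estimated at 40000 nM, within a range of 15000 nM to 100000 nM, and it is quite likely that the assay again reports only a limit for compound 3.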

Compound 3, concentration for 50% growth inhibition: 14100 nM
Compound 3: middle estimate off by 2.8-fold (0.45 log units), on the high side; the measured number lies below the stated range.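

Methoxy in place of hydrogen on a double-bonded ring carbon gives an at least 2.1-fold lower number from compound 2 to compound 3 (0.32 log units; beyond the scatter) in this assay, so a change at this position of the shared core can move growth inhibition in these cells. The only earlier step lay at the end of the chain and had a floor within the scatter, whereas this step is the first shown to go beyond it, and in the direction of stronger inhibition. Its printed size is only a floor, and the true step may be larger, because the value for compound 2 is a limit and not a number: the limit of > 30000 nM in this assay, at which 1 of the 3 values shown sits.

The compounds shown leave open whether methoxy is special at this ring carbon, or whether an ethoxy group, a longer alkoxy chain or an amine in the same place would give a similar step or none at all. They also leave open whether methoxy would give a comparable step on the chain end of compound 1, and they offer no measurement that explains why this step occurs.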